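This account rests on a few compounds, and the source may have more. Where it says the series, first, only, none or still open, it means among the compounds named here.

Measured in a functional assay on HCT-116 cells (Homo sapiens), read by MTT assay, with a stated time of 72 h; a lower number here means a stronger inhibitor, a higher number a weaker inhibitor:
Compound 1 (`C#Cc1cn([C@@H]2O[C@H](CO)[C@@H](O)[C@H]2O)c2ncnc(NC)c12`) gives > 20000 nM (a limit).
Compound 2 (`CN(C)c1ncnc2c1c(-c1ccoc1)cn2[C@@H]1O[C@H](CO)[C@@H](O)[C@H]1O`) gives > 20000 nM (a limit).
Compound 3 (`CN(C)c1ncnc2c1c(-c1ccsc1)cn2[C@@H]1O[C@H](CO)[C@@H](O)[C@H]1O`) gives > 20000 nM (a limit).
Not yet measured: compound 4 (`C#Cc1cn([C@@H]2O[C@H](CO)[C@@H](O)[C@H]2O)c2ncnc(N(C)C)c12`).

Compound 3 has no number on this scale, since its > 20000 nM is a limit of the assay and nothing more. Within the data shown here, the series as a whole offers only one reading so far, (the limit of > 20000 nM in this assay, at which 3 of the 3 values shown sit), so compound 3 cannot be ranked against the other two.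

The change under study is ethynyl in place of thiophen-3-yl on an aromatic carbon. Among the measured compounds shown here, one measured step bears on it directly: a step that the two limits leave unreadable from compound 2 to compound 3, which swaps one five-membered aromatic ring for another at this carbon and yields no size. Compound 1 also carries ethynyl on the shared core. Compound 1 gives > 20000 nM, again a limit.

With no readable step and an ethynyl example sitting at the limit, no step beyond the scatter and no direction is expected in this assay. The expected change is a step that the limit leaves unreadable from compound 3 to compound 4, and another limit is the likeliest report. For compound 4 the estimate is 25000 nM, with an expected range from 12000 nM to 60000 nM.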

Compound 4, half-maximal inhibitory concentration: 180 nM
For compound 4 the middle estimate is 140-fold (2.14 log units) above the measured one; the whole stated range lies above it.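

In this assay, the group on this aromatic carbon proves decisive once the nitrogen on the aromatic ring carries two methyls: ethynyl in place of thiophen-3-yl gives an at least 110-fold lower number from compound 3 to compound 4 (2.04 log units; beyond the scatter), and ethynyl in place of furan-3-yl gives an at least 110-fold lower number from compound 2 to compound 4 (2.04 log units; beyond the scatter). Ethynyl alone is not enough, however: methyl in place of hydrogen on that nitrogen gives an at least 110-fold lower number from compound 1 to compound 4 (2.04 log units; beyond the scatter), and among the compounds shown only ethynyl paired with the two methyls gives a measured value. Compound 1, compound 2 and compound 3 all stay at a single limit of the assay: the limit of > 20000 nM in this assay, at which 3 of the 4 values shown sit.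

The step between the two five-membered aromatic rings cannot be read, and the three steps to compound 4 are minimum sizes only, with their true sizes unknown. Going by these compounds, it also remains open whether the gain is specific to ethynyl or persists with a nitrile or a longer chain such as propynyl on this carbon, and whether an ethyl group or a longer chain on the nitrogen in place of methyl would hold the value.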